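Phenyl to 2-phenylethenyl on a shared core

This account rests on a few compounds, and the source may have more. Where it says the series, first, only, none or still open, it means among the compounds named here.

Of the compounds shown here, three have been measured in a functional assay on HT-29 cells (Homo sapiens) for cytotoxicity, read by MTT assay, with a stated time of 48 h; a lower number here means a stronger inhibitor, a higher number a weaker inhibitor. Compound 1 `O=C1C[C@H](OCc2cn(-c3ccc([N+](=O)[O-])cc3)nn2)[C@H]2CO[C@@H]1O2` gives 18300 nM, compound 2 `O=C1C[C@H](OCc2cc(-c3ccccc3)no2)[C@H]2CO[C@@H]1O2` gives 16900 nM, and compound 3 `O=C1C[C@H](OCc2cc(-c3ccc([N+](=O)[O-])cc3)no2)[C@H]2CO[C@@H]1O2` gives 19800 nM. Compound 2 holds the lowest of these three numbers, yet each of its gaps to the other two lies within the usual scatter, so no order among them can be read from the data. For the measured compounds named here, the only step between two compounds that differ in one place is a 1.2-fold higher number from compound 2 to compound 3 (0.07 log units; within the scatter), where a nitro group enters on an aromatic carbon of the phenyl group; it leaves the number essentially unchanged.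

Compound 4 `O=C1C[C@H](OCc2cc(/C=C/c3ccccc3)no2)[C@H]2CO[C@@H]1O2` differs from compound 2 in one place: 2-phenylethenyl in place of phenyl on an aromatic carbon. Going by the values given here, no measured pair shows what this particular exchange does, and the nitro step bears on it only loosely, as a sign that changes to this side group have so far stayed within the scatter. The expectation for compound 4 is therefore a number near that of compound 2, a step of a 1.0-fold higher number from compound 2 to compound 4 (0.00 log units; within the scatter). Compound 4 is estimated at 17000 nM in this assay, with a range from 6000 nM to 50000 nM.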

Compound 4, half-maximal inhibitory concentration: 13700 nM
Beside the measured number, compound 4's estimate is 1.2-fold (0.09 log units) above it, within the range that was stated.
By their numbers in this assay, from the lowest: compounds 4, 2, 1 and 3 (each within the scatter of the next).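

In this assay, the step of a 1.2-fold lower number from compound 2 to compound 4 (0.09 log units; within the scatter) concerns the group on the aromatic carbon next to the ring nitrogen, whereas the earlier step changed only a hydrogen on the phenyl group. It shows that this position accepts the larger 2-phenylethenyl group, with its double bond outside aromatic rings, and the number stays within the scatter of that of compound 2. Nothing here explains this result.

The compounds shown leave open whether the double bond matters, which 2-phenylethyl in the same place could test. They also leave open whether any group at this position can move the number beyond the scatter, for instance an amine, a carboxylic acid or a longer chain ending in a phenyl group.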